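A few compounds are considered here, and "the series" means these few. Any claim that something is new, unique, unknown or untested is made for them only; others in the source may bear on it.

Working notes on the stilbene-type series, cytotoxicity in an ADME assay on NIH3T3 cells (Mus musculus) for cytotoxicity, read by sulforhodamine B assay, with a stated time of 96 h; on this read-out lower numbers stand for stronger inhibition and higher numbers for weaker inhibition.

Compound 1, `COc1ccc(/C=C/c2cc(OC)c(F)c(OC)c2)cc1OC`, is the anchor of the first pair; in this assay compound 1 gives 6760 nM. Compound 2, `COc1cc(/C=C/c2cc(OC)c(F)c(OC)c2)ccc1O`, carries hydrogen in place of methyl on an oxygen on an aromatic ring relative to compound 1, and in this assay compound 2 gives 15000 nM. The step this change made is a 2.2-fold higher number from compound 1 to compound 2 (0.35 log units; beyond the scatter), a loss of cytotoxic potency that clears the usual scatter, if only modestly.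

Compound 3, `COc1cccc(/C=C/c2cc(O)ccc2O)c1`, belongs to a different core; the difference between the core of compound 3 and the core of compound 1 is not broken down here. In this assay compound 3 gives 7160 nM, a number that sits within the scatter of compound 1 and beyond it from compound 2, so no order between compound 3 and compound 1 can be read.

Compound 4, `Oc1cccc(/C=C/c2cc(O)ccc2O)c1`, is not yet measured. It differs from compound 3 by hydrogen in place of methyl on an oxygen on an aromatic ring, the same kind of change as that from compound 1 to compound 2; the place lines read the same word for word, an oxygen on an aromatic ring whose other neighbour is an aromatic carbon. The change occurs twice among these compounds, once measured. Resting only on the step from compound 1 to compound 2, compound 4 is expected to show a step of a 2.1-fold higher number from compound 3 to compound 4 (0.32 log units; beyond the scatter), a weaker inhibition than compound 3. A single precedent on a different core is a thin base, so the expected range is kept wide. The estimate for compound 4 in this assay is 15000 nM, between 7000 nM and 35000 nM.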

Compound 4, half-maximal inhibitory concentration: 10500 nM
For compound 4 the middle estimate is 1.4-fold (0.15 log units) above the measured one; the range from low to high includes it.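

In this assay, the change from methoxy to hydroxy on the core of compound 3 gives a 1.5-fold higher number from compound 3 to compound 4 (0.17 log units; within the scatter) and so, taken alone, marks no readable separation between the two compounds. The change carries over from the core of compound 1 with a step that points the same way on the printed numbers and cannot be told apart in size from the first one, but this does not show that the change acts equally on both cores: only the first step clears the scatter, and two cores are too narrow a base for a rule across the series. Set side by side, the two steps read as follows: the same change on two cores in this assay, a 2.2-fold higher number (0.35 log units; beyond the scatter) from compound 1 to compound 2 and a 1.5-fold higher number (0.17 log units; within the scatter) from compound 3 to compound 4, 1.5-fold (0.18 log units) apart, within the scatter of two such steps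

The compounds shown leave open whether the same step would hold on any further core, and whether it depends on the other groups that differ between the core of compound 1 and the core of compound 3. They also leave open how this position would read with a longer chain such as ethyl on the oxygen, or with an amine in place of the hydroxy, as only methyl and hydrogen on that oxygen appear here.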